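Alkynyl ether series: from propargyl to but-3-yn-1-yl

The compounds below may be only part of what the source reports. "The series", "measured", "known", "first", "only" and "open" are said of these compounds alone.

Measured in a functional assay on NCI-H292 cells (Homo sapiens) for inhibition, read by MTT assay, with a stated time of 72 h; on this read-out higher numbers stand for weaker inhibition and lower numbers for stronger inhibition:
- compound 1 `CC(C)O[C@@H]1C=CC(=O)[C@@H](CO)O1`: 24200 nM
- compound 2 `C#CCO[C@@H]1C=CC(=O)[C@@H](CO)O1`: 6600 nM

Of these two numbers, compound 2 has the lower, at 6600 nM, and therefore the stronger inhibition. Next step: compound 3 `C#CCCO[C@@H]1C=CC(=O)[C@@H](CO)O1`. The change from compound 2 is propargyl in place of ethynyl on a saturated chain carbon bound to an oxygen on a saturated carbon. Cut one bond further out, the same difference reads propargyl to but-3-yn-1-yl.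

Going by the values given here, only one measured step bears on this change: a 3.7-fold lower number from compound 1 to compound 2 (0.56 log units; beyond the scatter). It is modest but beyond the scatter, and it alters the same substituent on the oxygen. It does not cover the exchange at hand, so it gives no direction for it. In this assay, no step beyond the scatter is expected, and neither direction is favoured. The estimate means a 1.1-fold higher number from compound 2 to compound 3 (0.06 log units; within the scatter), with a wide margin on both sides. For compound 3, the estimated value is 7500 nM, with an expected range of 3000 nM to 19000 nM.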

Compound 3, half-maximal inhibitory concentration: 12700 nM
For compound 3 the middle estimate is 1.7-fold (0.23 log units) below the measured one; the measured number falls inside the stated range.
By their numbers in this assay, from the lowest: compounds 2, 3 and 1 (each within the scatter of the next, the first and the last beyond it).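

In this assay, but-3-yn-1-yl in place of propargyl on the oxygen gives no step beyond the scatter (a 1.9-fold higher number from compound 2 to compound 3 (0.28 log units; within the scatter)), so this position accepts a longer alkynyl chain without a readable loss or gain, which the earlier pair could not show. Going by these compounds alone, the same group in place of isopropyl also stays within the scatter (a 1.9-fold lower number from compound 1 to compound 3 (0.28 log units; within the scatter)), so compound 3 separates from neither neighbour, and the only step beyond the scatter remains the one between compound 1 and compound 2, which means the three compounds do not establish that an alkynyl ether as such is favoured over isopropyl at this oxygen. No measurement of any other kind is available to account for these numbers.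

The compounds shown leave open whether the triple bond itself matters, as a saturated n-propyl or n-butyl ether on the same oxygen would be needed to set against compound 2 and compound 3. Also open, on these data alone, is how far the chain can run, for example with pent-4-yn-1-yl, and whether a terminal amine or carboxylic acid on such a chain is accepted at this position.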